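Pyridin-4-yl for pyridin-3-yl, seen once, tried again

The compounds below may be only part of what the source reports. "The series", "measured", "known", "first", "only" and "open" are said of these compounds alone.

Compound 1 `Fc1ccc(-c2ccc3c(-c4cccnc4)cccc3c2)cc1`: 3%
Compound 2 `Fc1ccc(-c2ccc3c(-c4ccncc4)cccc3c2)cc1`: 28%
Compound 3 `Oc1ccc2cc(-c3cccc(-c4cccnc4)c3)ccc2c1`: 8%

In an assay for inhibition of steroid 17-alpha-hydroxylase/17,20 lyase (Homo sapiens), tested at 2 uM (on this read-out higher numbers stand for a stronger effect at the one concentration tested and lower numbers for a weaker effect), compound 1 gives 3% and compound 2 gives 28%. Compound 2 differs from compound 1 by pyridin-4-yl in place of pyridin-3-yl on an aromatic carbon, a change that brought a number 25 percentage points higher from compound 1 to compound 2 (beyond the scatter). Compound 3 gives 8% in this assay; how its core differs from the core of compound 1 is not broken down here. Compound 4 `Oc1ccc2cc(-c3cccc(-c4ccncc4)c3)ccc2c1` is still unmeasured and differs from compound 3 by pyridin-4-yl in place of pyridin-3-yl on an aromatic carbon. The two places are not the same word for word: in compound 1 the change sits on a ring that is part of a fused or bridged system of two rings, ortho to a fused ring and meta to a fused ring, whereas in compound 3 it sits meta to a large group. It is therefore the same kind of change, not the same. Resting on a number 25 percentage points higher from compound 1 to compound 2 (beyond the scatter), a step of a number 22 percentage points higher from compound 3 to compound 4 (beyond the scatter) is expected in this assay. Compound 4 is estimated at 30%, with 10% to 55% as the expected range.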

Compound 4, a percentage reported as inhibition, at one concentration (the size of the read-out at that concentration, not a potency): 66%
The estimate for compound 4 lay 36 percentage points below the measured number; the whole stated range lies below it.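

With a number 58 percentage points higher from compound 3 to compound 4 (beyond the scatter), pyridin-4-yl in place of pyridin-3-yl again gave a higher number in this assay. The direction of the change held on both cores, but its size did not carry from one core to the other: the same change on two cores in this assay, a number 25 percentage points higher (beyond the scatter) from compound 1 to compound 2 and a number 58 percentage points higher (beyond the scatter) from compound 3 to compound 4, 33 percentage points apart, beyond the scatter of two such steps. These two pairs show that the direction was shared on these two cores only; they give no reliable size for the step on a further core and do not show what sets the two steps apart.

The compounds shown leave open how the same change would run on a core bearing an amine or a carboxylic acid in place of the hydroxyl group of compound 4. They also leave open whether an imidazole ring could stand in for pyridin-4-yl.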